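The source may report more compounds than this note shows. Statements on the series, on what has been measured and on what is new or still open speak of the compounds shown alone.

Going by the values given here, compound 3, `Cc1nc(C(NC(=O)C(=O)Nc2ccc(Cl)cc2)C2CCCN2)sc1CO`, is the one compound of this set for which an ADME assay on MT2 cells (Homo sapiens) for cytotoxicity, read by XTT assay, with a stated time of 4 days (a higher number here means that more compound is tolerated, a lower number that less compound is tolerated), yields a number rather than a limit: in this assay compound 3 gives 45000 nM. Compound 1, `Cc1nc(C(NC(=O)C(=O)Nc2ccc(Cl)cc2)C2CCCCN2)sc1CO`, reaches only a limit, giving in this assay > 108000 nM. Compound 2, `CC(=O)N1CCCCC1C(NC(=O)C(=O)Nc1ccc(Cl)cc1)c1nc(C)c(CCO)s1`, likewise stops at a limit, giving in this assay > 84000 nM. Among the compounds with values here, the single step measured between compounds that differ in one place runs an at least 2.4-fold lower number from compound 1 to compound 3 (0.38 log units; beyond the scatter), a change in the saturated ring that does not touch the part of the molecule altered now. Compound 4, `Cc1nc(C(NC(=O)C(=O)Nc2ccc(Cl)cc2)C2CCCN2)sc1CCO`, differs from compound 3 by hydroxymethyl in place of hydroxy on a saturated chain carbon bound to an aromatic carbon. Within the data shown here, compound 1 and compound 2 carry hydroxymethyl and 2-hydroxyethyl groups on the shared core, yet they differ in a second place as well, so their pair offers no measured step for this change. Among the measured compounds shown here, no measured step therefore bears on the move from compound 3 to compound 4, and the expectation is a step in this assay of no more than the usual scatter, a 1.1-fold higher number from compound 3 to compound 4 (0.05 log units; within the scatter). For compound 4 in this assay the estimate is 50000 nM, with a range from 20000 nM to 120000 nM.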

Compound 4, half-maximal cytotoxic concentration: 42000 nM
Compound 4: middle estimate off by 1.2-fold (0.08 log units), on the high side, within the range that was stated.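

In this assay, going by these compounds alone, the step of a 1.1-fold lower number from compound 3 to compound 4 (0.03 log units; within the scatter) gives the first direct reading of hydroxymethyl against 2-hydroxyethyl on the shared core, and at this position the two chains cannot be told apart with the pyrrolidin-2-yl ring held fixed. Within the data shown here, compound 1 and compound 2 also carry these two chains, but they differ in a second place as well and both stop at limits, which leaves compound 3 and compound 4 as the only pair that isolates this change and gives a number for each member. The other new step, an at least 2.0-fold lower number from compound 2 to compound 4 (0.30 log units; that floor lies within the scatter), is only a floor that does not clear the scatter, because compound 2 stands at a limit: the limit of > 84000 nM in this assay, at which 1 of the 4 values shown sits.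

Going by these compounds, it remains open whether hydroxymethyl and 2-hydroxyethyl would also match in this assay with piperidin-2-yl or 1-acetylpiperidin-2-yl in place of pyrrolidin-2-yl on the saturated chain carbon. The compounds shown also leave open what a longer chain ending in hydroxy, a methyl ether or a carboxylic acid would give at this position.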